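Swapping the benzyl substituent on a weak amine oxidase inhibitor

The source may report more compounds than this note shows. Statements on the series, on what has been measured and on what is new or still open speak of the compounds shown alone.

Measured compounds:
compound 1, `Cc1ccc(COc2ccc(-c3nn(CCC#N)c(=O)o3)cc2)cc1`, 25000 nM
compound 2, `COc1cccc(COc2ccc(C3=NN(CCC#N)C(=O)CO3)cc2)c1`, 32000 nM

Of the compounds shown here, two have been measured in an assay for inhibition of Amine oxidase [flavin-containing] A (Rattus norvegicus); a lower number here means a stronger inhibitor, a higher number a weaker inhibitor. Compound 1 gives 25000 nM in this assay, and compound 2 gives 32000 nM. Compound 2 therefore has the highest of the two numbers, but its nearest neighbour, compound 1, sits within the usual scatter of it, so the two cannot be told apart on potency. Among the measured compounds shown here, no step between them is on record, since they differ in more than one place.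

Compound 3, `N#CCCN1N=C(c2ccc(OCc3ccc(Cl)cc3)cc2)OCC1=O`, has not yet been measured. It differs from compound 2 in a single place: 4-chlorophenyl in place of 3-methoxyphenyl on a saturated chain carbon bound to an oxygen on an aromatic ring. With only two weak inhibitors to go on, there is nothing to suggest that this exchange will move the number far; the expectation is for no step beyond the scatter, with at most a modest drift towards a lower number. Compound 3 is accordingly expected to give about 20000 nM in this assay, within a range of 5000 nM to 80000 nM. That estimate corresponds to a step of a 1.6-fold lower number from compound 2 to compound 3 (0.20 log units; within the scatter).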

Compound 3, half-maximal inhibitory concentration: 3400 nM
Beside the measured number, compound 3's estimate is 5.9-fold (0.77 log units) above it, outside the stated range (below it).
By their numbers in this assay, from the lowest: compound 3; then compounds 1 and 2 (each within the scatter of the next).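

In this assay, the 3-methoxybenzyl to 4-chlorobenzyl exchange on the core of compound 2 gives a 9.4-fold lower number from compound 2 to compound 3 (0.97 log units; beyond the scatter), showing that this position can move the number beyond the scatter. The earlier compounds shown here could not show this, since they differ in more than one place and offered no readable step. The exchange changes both the group on the ring and where it is named on the ring, so this single step cannot assign the gain to either change, and nothing on hand explains the fall in the number.

On these data alone, what remains open is whether the gain follows the chlorine or the position it occupies, which 4-methoxybenzyl and 3-chlorobenzyl on the same core would help to separate, while an unsubstituted benzyl would show how much either substituent contributes. As far as these compounds go, it is also open whether the same exchange would give a similar step on the core of compound 1, or whether a 4-bromobenzyl group would extend it further.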